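The source may hold more compounds than are shown below. What is called first, only, known or untested is meant among the compounds shown, and "the series" means these compounds.

Working notes on the series. In a functional assay on NCI-H1299 cells (Homo sapiens) for antiproliferative activity, read by XTT assay, with a stated time of 72 h (a lower number here means a stronger inhibitor, a higher number a weaker inhibitor), compound 1 `COc1ccc(-c2cc3ccccc3nc2/C=C/C(=O)c2ccc(F)cc2)cc1` gives 820 nM. Compound 2 `COc1ccc(-c2cc3ccccc3nc2/C=C/C(=O)c2ccc[nH]2)cc1` gives only > 10000 nM, a limit of this assay and not a number. That value sits at the limit of > 10000 nM in this assay, at which 1 of the 2 values shown sits. Within the data shown here, the one step measured, an at least 12-fold higher number from compound 1 to compound 2 (1.08 log units; beyond the scatter), is large and points to weaker inhibition. Compound 3 `COc1ccc(-c2cc3ccccc3nc2/C=C/C(=O)c2sccc2N)cc1` carries 3-aminothiophen-2-yl in place of 1H-pyrrol-2-yl on a carbonyl carbon. The entering group is again a five-membered aromatic ring on the carbonyl carbon, so the step from compound 2 is expected to be small: an at least 1.2-fold lower number from compound 2 to compound 3 (0.09 log units; that floor lies within the scatter). Compound 3 is therefore estimated at 8000 nM, with a range of 2000 nM to 30000 nM, and a real chance that only a limit is again reported.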

Compound 3, half-maximal inhibitory concentration: > 10000 nM
Compound 3: no number, only a limit; the forecaster's own chance of this, stated with the estimate: 50%; middle value at least 1.2-fold (0.09 log units) from the limit.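

Compared with compound 1, the 3-aminothiophen-2-yl group gives an at least 12-fold higher number from compound 1 to compound 3 (1.08 log units; beyond the scatter) in this assay, so a second five-membered aromatic ring on the carbonyl carbon also gives a large step towards weaker inhibition. This pattern rests on compound 2 and compound 3 alone, and the step between them cannot be read, as both values are limits. The floor of the readable range now holds most of the series: the limit of > 10000 nM in this assay, at which 2 of the 3 values shown sit.

As far as these compounds go, whether an unsubstituted phenyl or a thiophen-2-yl without the amine keeps activity at this carbonyl carbon remains open.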